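The compounds below may be only part of what the source reports. "The series", "measured", "known", "first", "only" and "open" are said of these compounds alone.

Compound 1, `CCc1cccc(NC(=O)N[C@@H](C)c2ccccc2)c1`: 94%
Compound 2, `CC(=O)c1cccc(NC(=O)N[C@H](C)c2ccccc2)c1`: 88%
Compound 3, `CC(=O)c1cccc(NC(=O)N[C@@H](C)c2ccccc2)c1`: 95%

In an ADME assay on the whole organism with Oryza sativa as the target, tested at 1 uM (a higher number here means a weaker effect of the compound at the concentration tested, a lower number a stronger effect), compound 3 has the highest of the three numbers, yet neither gap to the others reaches beyond the usual scatter: a number 1 percentage points higher from compound 1 to compound 3 (within the scatter) and a number 7 percentage points higher from compound 2 to compound 3 (within the scatter). Compound 4, `C[C@H](NC(=O)Nc1cccc(I)c1)c1ccccc1`, differs from compound 3 by one change, (iodo in place of acetyl on an aromatic carbon). For the measured compounds named here, only one measured step speaks to a swap of the group on that aromatic carbon, and it was flat: a number 1 percentage points higher from compound 1 to compound 3 (within the scatter). The other step, a change of configuration alone, does not apply here, since compound 4 keeps the drawn configuration of compound 3. The expected step is therefore none beyond the scatter, a number 2 percentage points lower from compound 3 to compound 4 (within the scatter). Compound 4 is estimated at 93%, within 82% to 100%.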

Compound 4, a percentage reported as activity, at one concentration (the size of the read-out at that concentration, not a potency): 95%
Estimate against measurement, compound 4: 2 percentage points below; the range from low to high includes it.
By their numbers in this assay, from the lowest: compounds 2, 1, 3 and 4 (each within the scatter of the next).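

In this assay, iodo, a single heavy atom with no hydrogen-bond acceptor, takes the place of the larger acetyl with its acceptor, and the step stays flat: no change at the digits printed from compound 3 to compound 4 (within the scatter). The comparison with ethyl is flat as well: a number 1 percentage points higher from compound 1 to compound 4 (within the scatter). Three different groups on this aromatic carbon, meta to a large group, thus stand within the scatter of one another, and nothing available accounts for this.

The compounds shown leave open whether an amine or a carboxylic acid at this place would separate from these readings. They also leave open whether iodo would read the same in the opposite drawn configuration.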